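Adding Bromine to Compound 3 in This Cytotoxicity Series

A few compounds are considered here, and "the series" means these few. Any claim that something is new, unique, unknown or untested is made for them only; others in the source may bear on it.

Compound 1 `Nc1nc(-c2ccccc2)cn1/N=C/c1cc2ccccc2nc1Cl` gives 49000 nM in a functional assay on MDA-MB-231 cells (Homo sapiens) for cytotoxicity, read by MTT assay, with a stated time of 48 h; a lower number here means a stronger inhibitor, a higher number a weaker inhibitor.
Compound 3 `Cc1ccc2nc(Cl)c(/C=N/n3cc(-c4ccccc4)nc3N)cc2c1` gives 48100 nM in this assay.
Compound 2 `Nc1nc(-c2ccc(Cl)cc2)cn1/N=C/c1cc2ccccc2nc1Cl` gives only a limit of the assay, > 50000 nM, not a number.

All three compounds were tested for cytotoxicity on the same breast cancer cell line, and all sit at the weak end of what the assay can report. Two steps connect them, both starting from compound 1: an at least 1.0-fold higher number from compound 1 to compound 2 (0.00 log units; that floor lies within the scatter) and a 1.0-fold lower number from compound 1 to compound 3 (0.01 log units; within the scatter). Among the measured compounds shown here, compound 3 thus holds the lowest of the two numbers, but its only numbered neighbour, compound 1, lies within the scatter of it, so no real order between them can be claimed; the third value is a limit (the limit of > 50000 nM in this assay, at which 1 of the 3 values shown sits).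

Compound 4 `Cc1ccc2nc(Cl)c(/C=N/n3cc(-c4ccc(Br)cc4)nc3N)cc2c1` has not yet been measured. It differs from compound 3 by bromo in place of hydrogen on an aromatic carbon. The step that bears on this is the earlier halogen change on the same phenyl ring, an at least 1.0-fold higher number from compound 1 to compound 2 (0.00 log units; that floor lies within the scatter), which did not lower the number and ended at the assay limit. A bromo group in the same place is therefore expected to give compound 4 a step of about a 1.1-fold higher number from compound 3 to compound 4 (0.06 log units; within the scatter), that is, no gain beyond the scatter and a fair chance of another limit. The estimated value for compound 4 is 55000 nM, within 30000 nM to 100000 nM.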

Compound 4, half-maximal inhibitory concentration: 38200 nM
Compound 4: middle estimate off by 1.4-fold (0.16 log units), on the high side; the range from low to high includes it.
By their numbers in this assay, from the lowest: compounds 4, 3 and 1 (each within the scatter of the next). At a limit, above all of these: compound 2.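

In this assay, placing bromo on the phenyl ring, para to a large group, gives a 1.3-fold lower number from compound 3 to compound 4 (0.10 log units; within the scatter), so the change from phenyl to 4-bromophenyl cannot be told apart from repeat-to-repeat variation. The only earlier halogen at this place ended differently: compound 2, with chloro there, gives > 50000 nM, which is a limit of the assay and not a number. Compound 4 does give a number, which shows that a halogen at this place does not always end at the limit, although a single bromo compound and a single chloro compound cannot show what separates the two outcomes.

No measurement shown here gives a reason for this small step, and no line of data bears on it. Still open, as far as these compounds go, is whether a group of another kind at this same place on the phenyl ring, such as an amine, a carboxylic acid or a longer chain, would move the number beyond the scatter, or whether this whole series stays at the weak end of what the assay can report.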